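A few compounds are considered here, and "the series" means these few. Any claim that something is new, unique, unknown or untested is made for them only; others in the source may bear on it.

Compound 1 `CCCCCCCCCCCCCCCCCC/N=c1\nc(N)c2nc[nH]c2c(N)n1` and compound 2 `CCCCCCCC/N=c1\nc(N)c2ncn(Cc3ccc(F)cc3)c2c(N)n1` share one core and differ in two places. In a functional assay on OVCAR-3 cells (Homo sapiens) for antiproliferative activity, read by WST assay, with a stated time of 72 h (a lower number here means a stronger inhibitor, a higher number a weaker inhibitor), compound 1 gives 3100 nM. In this assay compound 2 gives 4300 nM, the highest of the two numbers, yet within the scatter of compound 1. Compound 3 `CCCCCCCC/N=c1\nc(N)c2nc[nH]c2c(N)n1` awaits measurement. From compound 2 to compound 3 the change is hydrogen in place of 4-fluorobenzyl on an aromatic nitrogen. For the measured compounds named here, no measured pair isolates this step; since compound 1, with the bare ring nitrogen, gives 3100 nM, no step beyond the scatter is expected. For compound 3 the estimate is 3500 nM, range 1500 nM to 8000 nM. The expected step is a 1.2-fold lower number from compound 2 to compound 3 (0.09 log units; within the scatter).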

Compound 3, half-maximal inhibitory concentration: "not active" (no number reported)
For compound 3 the study gives words and no number, and the estimate cannot be compared.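

In this assay, for the compounds shown here, compound 3 is reported as "not active" without a number, so no step from compound 2 to compound 3 can be read. The compounds shown leave open how the 4-fluorobenzyl group and the chain length each bear on activity. Nothing shown bears on the cause of this result.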